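The compounds below may be only part of what the source reports. "The series", "measured", "known", "first", "only" and "open" are said of these compounds alone.

In an assay for inhibition of cytokinin dehydrogenase 2 (Arabidopsis thaliana) (a lower number here means a stronger inhibitor, a higher number a weaker inhibitor), compound 1 `COc1cccc(Nc2nc(F)nc3[nH]cnc23)c1` gives 1000 nM, the lowest of the two plain numbers in this set. Compound 3 `COc1cccc(Nc2nc(Cl)nc3c2ncn3C)c1` gives 61000 nM in this assay, a higher number that lies beyond the usual scatter. Compound 2 `COc1ccccc1Nc1nc(Cl)nc2[nH]cnc12` reaches only the limit of this assay, > 100000 nM (the limit of > 100000 nM in this assay, at which 1 of the 3 values shown sits), so no number is known for it. Compound 4 `COc1cccc(Nc2nc([N+](=O)[O-])nc3[nH]cnc23)c1` has not yet been measured in this assay. It differs from compound 1 by a nitro in place of fluoro on an aromatic carbon. For the measured compounds named here, no measured pair shows this exchange, so its effect is open. A step to a somewhat higher number is expected, a 3.0-fold higher number from compound 1 to compound 4 (0.48 log units; beyond the scatter), of moderate size. Compound 4 is therefore estimated at 3000 nM in this assay, within 500 nM to 20000 nM.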

Compound 4, half-maximal inhibitory concentration: 14000 nM
Compound 4: middle estimate off by 4.7-fold (0.67 log units), on the low side, within the range that was stated.
By their numbers in this assay, from the lowest: compound 1; then compound 4; then compound 3. At a limit, above all of these: compound 2.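

For the compounds shown here, the first single-place change in this set shows that the aromatic carbon between two ring nitrogen atoms is sensitive to what it carries: in this assay nitro in place of fluoro gives a 14-fold higher number from compound 1 to compound 4 (1.15 log units; beyond the scatter) on an otherwise unchanged core. Nothing measured here accounts for the size of this step. On these data alone, whether an amine or a nitrile on this carbon would stay close to compound 1 remains open, and a single exchange cannot establish a trend across groups.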